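The source may hold more compounds than are shown below. What is called first, only, known or untested is meant among the compounds shown, and "the series" means these compounds.

Of the compounds shown here, two of a shared core have been measured in a functional assay on UACC-62 cells (Homo sapiens) for inhibition, read by sulforhodamine B assay, with a stated time of 48 h; on this read-out lower numbers stand for stronger inhibition of growth and higher numbers for weaker inhibition of growth. Compound 1 `COc1ccc(-c2cc(/C=C/C(=O)c3ccc(N)cc3)[nH]n2)cc1` gives 2940 nM in this assay. Compound 2 `COc1cc(-c2cc(/C=C/C(=O)c3ccc(N)cc3)[nH]n2)cc(OC)c1OC` gives 3580 nM in this assay, the higher of the two numbers, but its nearest neighbour, compound 1, lies within the scatter of it, so the two values show no real difference. Compound 3 `COc1ccc(-c2cc(/C=C/C(=O)c3ccc(N)cc3)[nH]n2)cc1OC` is not yet measured; compared with compound 2 the change is hydrogen in place of methoxy on an aromatic carbon, with hydrogen in place of methoxy on an aromatic carbon. The measured compounds differ only in methoxy substitution on that same ring and sit within the scatter of each other, so no change beyond the scatter is expected from compound 2 to compound 3, an expected step of a 1.1-fold lower number from compound 2 to compound 3 (0.05 log units; within the scatter). Compound 3 is therefore estimated at 3200 nM, with an expected range from 1600 nM to 6400 nM.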

Compound 3, concentration for total growth inhibition: 10900 nM
Compound 3: middle estimate off by 3.4-fold (0.53 log units), on the low side, outside the stated range (above it).
By their numbers in this assay, from the lowest: compounds 1 and 2 (each within the scatter of the next); then compound 3.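

Replacing one methoxy with hydrogen, on an aromatic carbon ortho to a methoxy group and meta to a large group, gives a 3.0-fold higher number from compound 2 to compound 3 (0.48 log units; beyond the scatter) in this assay and so shows that this position can matter for growth inhibition. Going the other way, methoxy in place of hydrogen gives a 3.7-fold higher number from compound 1 to compound 3 (0.57 log units; beyond the scatter) at a different place on the ring, so compound 3 is the weakest of the three and the number of methoxy groups alone does not set the order. Nothing shown here explains why this particular pattern of methoxy groups does worse.

As far as these compounds go, the ring carries only methoxy and hydrogen in these compounds, so it remains open whether a hydroxyl, a fluorine or a longer chain such as ethoxy would act like either one. From the compounds shown here alone, whether the same pattern would hold in other cell lines also remains open.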